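Predicting a dibromo-hydroxyphenyl analogue from a dichlorophenyl step

The source may report more compounds than this note shows. Statements on the series, on what has been measured and on what is new or still open speak of the compounds shown alone.

Measured so far:
- compound 1, `COc1ccc(/C=N/NC(=O)Nc2ccc(Oc3ccnc(-c4nncn4CCN(C)C)c3)c(F)c2)c(OC)c1OC`: 1790 nM
- compound 2, `CN(C)CCn1cnnc1-c1cc(Oc2ccc(NC(=O)N/N=C/c3cccc(Cl)c3Cl)cc2F)ccn1`: 72 nM

Both compounds share one core and differ only in the ring attached to the carbon that carries a double bond to nitrogen. In a functional assay on NCI-H460 cells (Homo sapiens) for cytotoxicity, read by MTT assay, with a stated time of 72 h (a higher number here means a weaker inhibitor, a lower number a stronger inhibitor), compound 1 gives 1790 nM, the highest of the two numbers, while compound 2 gives 72 nM. Among the compounds with values here, the one step measured, a 25-fold lower number from compound 1 to compound 2 (1.40 log units; beyond the scatter), is large and well beyond the scatter.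

Compound 3, `CN(C)CCn1cnnc1-c1cc(Oc2ccc(NC(=O)N/N=C/c3cc(Br)c(O)c(Br)c3)cc2F)ccn1`, is not yet measured. It differs from compound 1 as follows: 3,5-dibromo-4-hydroxyphenyl in place of 2,3,4-trimethoxyphenyl on a carbon with a double bond to nitrogen. Like compound 2, it carries a phenyl bearing two halogens in place of the trimethoxyphenyl, though the substitution pattern and the added hydroxyl differ. Because of a 25-fold lower number from compound 1 to compound 2 (1.40 log units; beyond the scatter), a lower number is expected for compound 3, though a smaller step is estimated, a 6.0-fold lower number from compound 1 to compound 3 (0.78 log units; beyond the scatter). Compound 3 is therefore estimated at 300 nM, within 80 nM to 1200 nM.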

Compound 3, half-maximal inhibitory concentration: 3760 nM
For compound 3 the middle estimate is 13-fold (1.10 log units) below the measured one; measured number above the stated range.
By their numbers in this assay, from the lowest: compound 2; then compound 1; then compound 3.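

Two halogens on this ring do not by themselves give a low number in this assay: replacing 2,3-dichlorophenyl with 3,5-dibromo-4-hydroxyphenyl gives a 52-fold higher number from compound 2 to compound 3 (1.72 log units; beyond the scatter), and replacing 2,3,4-trimethoxyphenyl with the same group gives a 2.1-fold higher number from compound 1 to compound 3 (0.32 log units; beyond the scatter). The ring on the carbon with a double bond to nitrogen therefore matters in more detail than the earlier pair could show, since the 3,5-dibromo-4-hydroxyphenyl group ends up with the highest number of the three despite carrying two halogens. Nothing available here explains this difference.

The change from compound 2 to compound 3 alters the halogen, its placing and the hydroxyl all at once, so the compounds shown cannot say which of these matters. A dibromophenyl group without the hydroxyl, or a hydroxyphenyl group without bromine, would help to separate them.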